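Swapping the piperazine for an imidazole in a hydrazide series

This account rests on a few compounds, and the source may have more. Where it says the series, first, only, none or still open, it means among the compounds named here.

Of the compounds shown here, three sharing one core have been tested in a functional assay on thoracic aorta (Rattus norvegicus, strain Wister); a lower number here means a stronger inhibitor, a higher number a weaker inhibitor. Compound 1 `O=C(CN1CCN(c2ccc(Cl)cc2)CC1)NNc1nncc2ccccc12` gives 450000 nM. Compound 2 `CN1CCN(CC(=O)NNc2nncc3ccccc23)CC1` gives 160000 nM. Compound 3 `CCOC(=O)N1CCN(CC(=O)NNc2nncc3ccccc23)CC1` reaches only a limit of the assay, > 1000000 nM. Among the two actual numbers compound 2 stands lowest, and its nearest neighbour is compound 1, the difference being a 2.8-fold lower number from compound 1 to compound 2 (0.45 log units; beyond the scatter). The other steps, an at least 2.2-fold higher number from compound 1 to compound 3 (0.34 log units; beyond the scatter) and an at least 6.2-fold higher number from compound 2 to compound 3 (0.79 log units; beyond the scatter), both run toward the limit (the limit of > 1000000 nM in this assay, at which 1 of the 3 values shown sits).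

Compound 4 `O=C(Cn1ccnc1)NNc1nncc2ccccc12` has not yet been measured. It differs from compound 2 by 1H-imidazol-1-yl in place of 4-methylpiperazin-1-yl on a saturated chain carbon bound to a carbonyl carbon. Among the compounds with values here, none of the measured steps removes the whole ring; each only changes the group on its nitrogen, so they bear on this step only loosely. Two of those three steps raised the number, one lowered it. The step of a 2.2-fold higher number from compound 2 to compound 4 (0.34 log units; beyond the scatter) is therefore expected to be a modest rise, though with wide uncertainty. Compound 4 is expected to give about 350000 nM, within a range from 100000 nM to 1200000 nM.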

Compound 4, half-maximal inhibitory concentration: 610000 nM
For compound 4 the middle estimate is 1.7-fold (0.24 log units) below the measured one; low and high end bracket the measured number.
By their numbers in this assay, from the lowest: compound 2; then compounds 1 and 4 (each within the scatter of the next). At a limit, above all of these: compound 3.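

The earlier steps shown here only changed the group on the ring nitrogen, whereas this one replaces the whole ring, and in this assay it gives a 3.8-fold higher number from compound 2 to compound 4 (0.58 log units; beyond the scatter). A five-membered aromatic ring, 1H-imidazol-1-yl, can therefore stand in place of the six-membered non-aromatic 4-methylpiperazin-1-yl on a saturated chain carbon bound to a carbonyl carbon and still give a measurable number, although compound 2 keeps the lowest number of the series. Nothing in the data available explains this rise.

The compounds shown do not separate the effect of ring size from that of the aromatic ring, since both change in this one step. A pyrrolidine or a morpholine on the same chain carbon would help to tell these two changes apart.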